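Pyrrole-linked dihydroxyheptenoic acids: meta-chloro on the phenyl

The compounds below may be only part of what the source reports. "The series", "measured", "known", "first", "only" and "open" are said of these compounds alone.

Measured so far in an assay on isolated protein for inhibition of 3-hydroxy-3-methylglutaryl-coenzyme A reductase (Homo sapiens); a lower number here means a stronger inhibitor, a higher number a weaker inhibitor:
compound 1 `Cc1cc(C)cc(-c2c(-c3ccc(F)cc3)nc(C(C)C)n2/C=C/[C@@H](O)C[C@@H](O)CC(=O)O)c1`: 7.25 nM
compound 2 `CC(C)c1cc(-c2ccc(F)cc2)c(-c2ccc(F)cc2)n1/C=C/[C@@H](O)C[C@@H](O)CC(=O)O`: 8.7 nM; 6.98 nM (2 entries)
compound 3 `CC(C)c1cc(-c2ccc(F)cc2)c(-c2ccccc2)n1/C=C/[C@@H](O)C[C@@H](O)CC(=O)O`: 7.6 nM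

Compound 3 holds the higher of the two single numbers, but its gap to compound 1 is within the scatter, so the two stand level. Compound 2 is known only through several entries, (the several entries of compound 2 in this assay, 8.7 nM; 6.98 nM (2 entries)), which bracket the same region.

Compound 4 `CC(C)c1cc(-c2ccc(F)cc2)c(-c2cccc(Cl)c2)n1/C=C/[C@@H](O)C[C@@H](O)CC(=O)O` differs from compound 3 by chloro in place of hydrogen on an aromatic carbon; one bond further out, phenyl becomes 3-chlorophenyl. Among the measured compounds shown here, no measured pair shows this kind of change, so no step beyond the scatter is expected in this assay in either direction. For compound 4 the expected value is 7.5 nM, between 3.5 nM and 16 nM, an estimated step of a 1.0-fold lower number from compound 3 to compound 4 (0.01 log units; within the scatter).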

Compound 4, half-maximal inhibitory concentration: 7.15 nM
Compound 4: the middle estimate sits 1.0-fold (0.02 log units) above what was measured; measured number inside the range.
By their numbers in this assay, from the lowest: compounds 4, 1 and 3 (each within the scatter of the next).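

In this assay, among the compounds shown here, the first step that changes one place reads a 1.1-fold lower number from compound 3 to compound 4 (0.03 log units; within the scatter). This position, on an aromatic carbon meta to a large group, therefore accepts chloro in place of hydrogen with no change that can be told from the scatter. No measurement at hand bears on why the number stays level.

As far as these compounds go, whether this holds for other groups here, such as methoxy, an amine or a carboxylic acid, remains open. So does the effect of chloro elsewhere on the same ring.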